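Benzyl swap on the shared core: chloro for fluoro

The source may report more compounds than this note shows. Statements on the series, on what has been measured and on what is new or still open speak of the compounds shown alone.

Measured in a functional assay on HL-60 cells (Homo sapiens) for antiproliferative activity, with a stated time of 72 h; a higher number here means a weaker inhibitor, a lower number a stronger inhibitor:
- compound 1 `Cc1cccc(CNc2ncnc3c2ncn3[C@@H]2O[C@H](CO)[C@@H](O)[C@H]2O)c1`: 6400 nM
- compound 2 `OC[C@H]1O[C@@H](n2cnc3c(NCc4ccc(F)cc4F)ncnc32)[C@H](O)[C@@H]1O`: 3400 nM

Compound 2, at 3400 nM, is within the scatter of compound 1, so the two values cannot be ranked. Compound 3 `OC[C@H]1O[C@@H](n2cnc3c(NCc4ccc(F)cc4Cl)ncnc32)[C@H](O)[C@@H]1O` differs from compound 2 by chloro in place of fluoro on an aromatic carbon. This is chloro in place of fluoro on an aromatic carbon, turning 2,4-difluorobenzyl into 2-chloro-4-fluorobenzyl.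

Within the data shown here, only one measured step bears on this change. That step, a 1.9-fold lower number from compound 1 to compound 2 (0.27 log units; within the scatter), places 2,4-difluorophenyl where 3-methylphenyl stood and remains within the scatter. It is a larger replacement than the exchange of a single atom, so no step beyond the scatter is expected in this assay.

The estimated change is a 1.1-fold lower number from compound 2 to compound 3 (0.05 log units; within the scatter), which is expected to lie within the scatter. For compound 3 the expected value is 3000 nM, with an estimated range of 1400 nM to 6500 nM.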

Compound 3, half-maximal inhibitory concentration: 9000 nM
The estimate for compound 3 lay 3.0-fold (0.48 log units) below the measured number; measured number above the stated range.
By their numbers in this assay, from the lowest: compounds 2, 1 and 3 (each within the scatter of the next, the first and the last beyond it).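

In this assay, among these compounds, the exchange of a single atom gives the first step beyond the scatter, though a modest one (a 2.6-fold higher number from compound 2 to compound 3 (0.42 log units; beyond the scatter)). Chloro for fluoro on an aromatic carbon ortho to a large group therefore registers at this position, while the wider replacement of the 3-methylphenyl group by 2-chloro-4-fluorophenyl stays within the scatter (a 1.4-fold higher number from compound 1 to compound 3 (0.15 log units; within the scatter)). Nothing available bears on why the single-atom exchange gives the higher number.

The compounds shown leave open whether bromo, methyl or methoxy at this position would follow chloro or fluoro. They also leave open whether the step from fluoro to chloro would be the same size in a benzyl group without the fluoro that stays in place in compound 2 and compound 3.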